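The compounds below may be only part of what the source reports. "The series", "measured", "known", "first", "only" and "open" are said of these compounds alone.

Compound 1, `COC(=O)c1sc2cc(-c3ccc(C#N)cc3)cnc2c1N`, in a functional assay on NCI-H460 cells (Homo sapiens) for inhibition, read by sulforhodamine B assay, with a stated time of 48 h (on this read-out higher numbers stand for weaker inhibition of growth and lower numbers for stronger inhibition of growth), gives > 75000 nM, a limit of the assay.
Compound 2, `COC(=O)c1sc2cc(-c3ccc(C(C)=O)cc3)cnc2c1N`, in this assay gives > 150000 nM, a limit of the assay.
Compound 3, `COC(=O)c1sc2cc(-c3ccc(C(F)(F)F)cc3)cnc2c1N`, in this assay gives > 150000 nM, a limit of the assay.

Compound 3 therefore stands only at a limit, as do the other two values, which sit at the limit of > 150000 nM in this assay, at which 2 of the 3 values shown sit, and (the limit of > 75000 nM in this assay, at which 1 of the 3 values shown sits). Compound 4, `COC(=O)c1sc2cc(-c3ccc(OC)cc3)cnc2c1N`, differs from compound 3 by methoxy in place of trifluoromethyl on an aromatic carbon. Among the measured compounds shown here, the steps that bear on this change are a step that the two limits leave unreadable from compound 1 to compound 3, a step that the two limits leave unreadable from compound 2 to compound 3 and a step that the two limits leave unreadable from compound 1 to compound 2, none of which the limits allow to be read. No readable step is therefore expected in this assay, and compound 4 is expected to give 150000 nM, between 40000 nM and 400000 nM, most likely again as a limit; this means an expected step of a number no higher from compound 3 to compound 4 (the limit leaves the size open).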

Compound 4, concentration for 50% growth inhibition: > 150000 nM
Compound 4: only a limit was reported; the forecaster's own chance of this, stated with the estimate: 75%; the middle value sits exactly at the limit.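

Compound 4 gives only a limit in this assay, as do compound 1, compound 2 and compound 3, so no step among them can be read: the limit of > 150000 nM in this assay, at which 3 of the 4 values shown sit.

The compounds shown leave open whether any of these groups differ in their inhibition of growth, and by how much.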